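A few compounds are considered here, and "the series" means these few. Any claim that something is new, unique, unknown or untested is made for them only; others in the source may bear on it.

Compound 2 `O=c1cc(-c2ccc(O)c(O)c2)oc2cc(OCCO)ccc12` is one of two compounds tested in a functional assay for inhibition, with Rattus norvegicus as the target, using microsomes; on this read-out lower numbers stand for stronger inhibition and higher numbers for weaker inhibition. For the measured compounds named here, compound 2 gives 16400 nM, and the only other compound, compound 1 `O=c1cc(-c2ccc(O)c(O)c2)oc2cc(O)ccc12`, gives 11000 nM; the measured change from one to the other, a 1.5-fold higher number from compound 1 to compound 2 (0.17 log units; within the scatter), separates them. Compound 3 `CN(C)CCCOc1ccc2c(=O)cc(-c3ccc(O)c(O)c3)oc2c1` differs from compound 2 by (dimethylamino)methyl in place of hydroxy on a saturated chain carbon, two bonds along the chain from an oxygen on an aromatic ring. Going by the values given here, the single measured step altered the same chain on the same oxygen and hardly moved the number, but no step tests an amine on that chain. The expected step is therefore a 1.2-fold lower number from compound 2 to compound 3 (0.07 log units; within the scatter), nothing beyond the scatter. Compound 3 is estimated at 14000 nM, within 5000 nM to 40000 nM.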

Compound 3, half-maximal inhibitory concentration: 8100 nM
Compound 3: middle estimate off by 1.7-fold (0.24 log units), on the high side; the measured number falls inside the stated range.
By their numbers in this assay, from the lowest: compounds 3, 1 and 2 (each within the scatter of the next, the first and the last beyond it).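

For the compounds shown here, on this chain the end group does matter a little: in this assay, (dimethylamino)methyl in place of hydroxy gives a 2.0-fold lower number from compound 2 to compound 3 (0.31 log units; beyond the scatter) and is the first step here beyond the scatter, though only a modest one. Set against hydrogen on the same oxygen, the 3-(dimethylamino)propyl group gives a 1.4-fold lower number from compound 1 to compound 3 (0.13 log units; within the scatter) and so shows no clear difference. No evidence is available to explain the step. Still open, as far as these compounds go, is whether a carboxylic acid at the chain end, or a longer chain carrying the same amine, would behave differently.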